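The compounds below may be only part of what the source reports. "The series", "measured", "known", "first", "only" and "open" are said of these compounds alone.

Working notes on the series. In a functional assay on the whole organism with Scenedesmus acutus as the target, with a stated time of 20 h (a lower number here means a stronger inhibitor, a higher number a weaker inhibitor), compound 1 (`Cc1cc(Cl)ccc1/N=c1\sc(=S)n2n1CCCC2`) gives 513 nM and compound 2 (`S=c1s/c(=N\c2ccc(OCc3ccc(Cl)cc3)cc2)n2n1CCCC2`) gives 120 nM while compound 3 (`S=c1s/c(=N\c2ccc(Br)cc2)n2n1CCCC2`) gives 550 nM on the same read-out. Compound 3 therefore lies within the scatter of compound 1, and compound 2 has the lower number, beyond the scatter from compound 3. For the measured compounds named here, no two measured compounds differ in one place only, so no direct step is available for comparison.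

Compound 4 (`S=c1s/c(=N\c2ccc(Cl)cc2)n2n1CCCC2`) carries chloro in place of bromo on an aromatic carbon, para to a large group. Compound 1 also carries a chloro on its aromatic ring and gives 513 nM within the scatter of compound 3, though it differs from compound 4 in more than this group. The expected step of a 1.0-fold lower number from compound 3 to compound 4 (0.02 log units; within the scatter) is none beyond the scatter in this assay with neither direction favoured. For compound 4 the estimate is 530 nM with 260 nM to 1050 nM as the expected range.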

Compound 4, half-maximal inhibitory concentration: 550 nM
Beside the measured number, compound 4's estimate is 1.0-fold (0.02 log units) below it; low and high end bracket the measured number.
By their numbers in this assay, from the lowest: compound 2; then compounds 1, 3 and 4 (each within the scatter of the next).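

In this assay, chloro in place of bromo on an aromatic carbon, para to a large group, gives no change at the digits printed from compound 3 to compound 4 (within the scatter) and so does not separate the two halogens at this position. Hydrogen in place of methyl on an aromatic carbon gives a 1.1-fold higher number from compound 1 to compound 4 (0.03 log units; within the scatter) and is the first one-place reading for the methyl group, which leaves the number within the scatter when chloro is kept on the ring. No measurement at hand bears on why either step is this small.

From the compounds shown here alone, whether an amine or a carboxylic acid at the same position would leave the number where the two halogens put it remains open. Also open, going by these compounds, is whether a methyl group would give the same reading on a ring carrying bromo rather than chloro.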